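The source may hold more compounds than are shown below. What is called first, only, known or untested is meant among the compounds shown, and "the series" means these compounds.

Compound 1 `CC(C)(C)c1cc(C(C)(C)C)c2oc(=O)c(/C=N/c3ccc(S(N)(=O)=O)cc3)c(Cl)c2c1` carries two tert-butyl groups on its core, and in a functional assay on B16-F10 cells (Mus musculus) for cytotoxicity, read by CCK-8 assay, with a stated time of 48 h (a lower number here means a stronger inhibitor, a higher number a weaker inhibitor), compound 1 gives 240 nM. Compound 2 `CC(C)(C)c1cc(C(C)(C)C)c2oc(=O)c(/C=N/c3ccc(S(=O)(=O)Nc4nccs4)cc3)c(Cl)c2c1` differs from it in one place, (1,3-thiazol-2-yl in place of hydrogen on a sulfonamide nitrogen). In this assay compound 2 gives 160 nM. That step, a 1.5-fold lower number from compound 1 to compound 2 (0.18 log units; within the scatter), shows the change making at most a small difference here.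

Compound 3 `Cc1ccc2oc(=O)c(/C=N/c3ccc(S(N)(=O)=O)cc3)c(Cl)c2c1` has a methyl group on its core instead of the two tert-butyl groups; how its core differs from that of compound 1 is not broken down here. In this assay compound 3 gives 360 nM, which stands within the scatter of the value of compound 1.

Compound 4 `Cc1ccc2oc(=O)c(/C=N/c3ccc(S(=O)(=O)Nc4nccs4)cc3)c(Cl)c2c1` is the unmeasured partner: it differs from compound 3 by 1,3-thiazol-2-yl in place of hydrogen on a sulfonamide nitrogen, the same change that turned compound 1 into compound 2. Because that earlier step, a 1.5-fold lower number from compound 1 to compound 2 (0.18 log units; within the scatter), stayed within the scatter, the step from compound 3 to compound 4 is expected to be of similar size, a 1.5-fold lower number from compound 3 to compound 4 (0.18 log units; within the scatter). On that basis compound 4 is estimated at 240 nM, with a likely range from 130 nM to 450 nM in this assay.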

Compound 4, half-maximal inhibitory concentration: 280 nM
Beside the measured number, compound 4's estimate is 1.2-fold (0.07 log units) below it; low and high end bracket the measured number.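

In this assay, putting 1,3-thiazol-2-yl in place of hydrogen on the sulfonamide nitrogen of compound 3 gives a 1.3-fold lower number from compound 3 to compound 4 (0.11 log units; within the scatter), so the change again makes at most a small difference. Set side by side, the steps on the two cores do not differ: the same change on two cores in this assay, a 1.5-fold lower number (0.18 log units; within the scatter) from compound 1 to compound 2 and a 1.3-fold lower number (0.11 log units; within the scatter) from compound 3 to compound 4, 1.2-fold (0.07 log units) apart, within the scatter of two such steps. This shows that the small size of the step carries over between these two cores, but it does not show that the change truly improves the number on either one, and two cores cannot establish how it would behave on a third.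

The compounds shown leave open whether another group on the sulfonamide nitrogen, such as an acetyl group or a longer alkyl chain, would give a step beyond the scatter. They also leave open whether the thiazolyl step stays this small on a core carrying a methoxy group or a carboxylic acid in place of the methyl or the two tert-butyl groups.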